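The source may hold more compounds than are shown below. What is called first, only, known or untested is meant among the compounds shown, and "the series" means these compounds.

Compound 1 `NNC(=O)COc1ccncc1-c1ccc2ccccc2c1` gives 19% in an assay on a protein complex for inhibition of CDK8/Cyclin C (Homo sapiens), with a stated time of 1 h, tested at 10 uM (a higher number here means more inhibition at the concentration tested (going by the name of the read-out), a lower number less inhibition), the lowest of the two numbers at hand. Compound 2 `CCOC(=O)/C=C/c1ccncc1-c1ccc2cc[nH]c2c1` gives 104% in this assay, a number beyond the scatter above compound 1; the two compounds differ in more than one place, so only their values can be set side by side. Compound 3 `CNC(=O)COc1ccncc1-c1ccc2ccccc2c1` has not been measured yet; it differs from compound 1 by methyl in place of amino on an amide-type nitrogen. Going by the values given here, no measured pair shows this change. A step of no more than the scatter, in no particular direction, is expected, a number 1 percentage points higher from compound 1 to compound 3 (within the scatter). Compound 3 is therefore estimated at 20%, between 0% and 45%.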

Compound 3, a percentage reported as inhibition, at one concentration (the size of the read-out at that concentration, not a potency): 4%
For compound 3 the middle estimate is 16 percentage points above the measured one; the range from low to high includes it.
By their numbers in this assay, from the lowest: compound 3; then compound 1; then compound 2.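

In this assay, methyl in place of amino on the amide-type nitrogen gives a number 15 percentage points lower from compound 1 to compound 3 (beyond the scatter), the first step read in one place, and it shows that the number at this position responds to this change. The step is modest and runs downward, so amino is the better of the two groups here. No available evidence bears on what lies behind this drop.

From the compounds shown here alone, whether an ethyl group, a hydroxyl or a longer chain on this nitrogen would restore or further lower the number remains open. So does whether the same change would give a similar step on another core.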